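Urea series: hydroxypyrrolidine against hydroxycyclohexylmethyl amine

The source may report more compounds than this note shows. Statements on the series, on what has been measured and on what is new or still open speak of the compounds shown alone.

Measured compounds:
compound 1 `O=C(NC1CCN(Cc2ccn(-c3ccc(C(F)(F)F)cc3)c2)CC1)N1CC[C@@H](O)C1` 138 nM
compound 2 `O=C(NC[C@@H]1CCCC[C@H]1O)NC1CCN(Cc2ccn(-c3ccc(C(F)(F)F)cc3)c2)CC1` 46 nM
compound 3 `O=C(NC1CCN(Cc2ccn(-c3ccc(C(F)(F)F)cc3)c2)CC1)N1CCC(c2ccccc2O)CC1` 36 nM

All three share a core and differ only in the group on the urea carbonyl. In an assay on HEK293 cells for displacement of a labelled ligand from melanin-concentrating hormone receptor 1 (Homo sapiens) (a lower number here means a stronger inhibitor, a higher number a weaker inhibitor), compound 2 gives 46 nM, the second highest of the three numbers; compound 3 sits nearest, within the scatter, and compound 1 lies furthest, beyond it. The single step that connects two of these compounds at this position is a 3.0-fold lower number from compound 1 to compound 2 (0.48 log units; beyond the scatter), a modest gain when ((2-hydroxycyclohexyl)methyl)amino replaces 3-hydroxypyrrolidin-1-yl.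

Compound 4 `O=C(NC1CCN(Cc2ccn(-c3ccc(C(F)(F)F)cc3)c2)CC1)N1CC[C@H](O)C1` is not yet measured. It differs from compound 2 as follows: 3-hydroxypyrrolidin-1-yl in place of ((2-hydroxycyclohexyl)methyl)amino on a carbonyl carbon. Among the measured compounds shown here, this is the reverse of the one measured step, with the 3-hydroxypyrrolidin-1-yl group now carrying the opposite configuration at its one defined stereocentre compared with compound 1. Nothing measured here tells how that configuration matters, so the value of compound 1, 138 nM, is the closest guide, and the step back from compound 2 is expected to be about as large as the one seen going forward. Compound 4 is therefore expected to give 130 nM, within 50 nM to 400 nM, which would mean a 2.8-fold higher number from compound 2 to compound 4 (0.45 log units; beyond the scatter).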

Compound 4, half-maximal inhibitory concentration: 125 nM
Estimate against measurement, compound 4: 1.0-fold (0.02 log units) above; the measured number falls inside the stated range.
By their numbers in this assay, from the lowest: compounds 3 and 2 (each within the scatter of the next); then compounds 4 and 1 (each within the scatter of the next).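

In this assay, the two configurations of the 3-hydroxypyrrolidin-1-yl group cannot be told apart, with a 1.1-fold lower number from compound 1 to compound 4 (0.04 log units; within the scatter), so at this position on the carbonyl carbon the drawn stereocentre has no readable effect on the number. The disadvantage of 3-hydroxypyrrolidin-1-yl against ((2-hydroxycyclohexyl)methyl)amino therefore holds for both configurations, with a 2.7-fold higher number from compound 2 to compound 4 (0.43 log units; beyond the scatter) similar in size to the earlier 3.0-fold lower number from compound 1 to compound 2 (0.48 log units; beyond the scatter). The stereochemical reading rests on a direct comparison with no other structural change: the fact that compounds 1 and 4 differ only in the configuration as drawn.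

As far as these compounds go, it remains open whether the hydroxyl group contributes at this position at all, a question that plain pyrrolidin-1-yl, 3-methoxypyrrolidin-1-yl or 3-aminopyrrolidin-1-yl on the same carbonyl carbon would address. Also open, from the compounds shown here alone, is what in ((2-hydroxycyclohexyl)methyl)amino separates it from 3-hydroxypyrrolidin-1-yl, and whether that group is sensitive to its own two stereocentres, which the other stereoisomers of ((2-hydroxycyclohexyl)methyl)amino and the simpler cyclohexylmethylamino group would help to settle.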